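Nitro Gives Way to Fluoro on the Shared Core

The source may report more compounds than this note shows. Statements on the series, on what has been measured and on what is new or still open speak of the compounds shown alone.

In a functional assay on HCT-116 cells (Homo sapiens) for antiproliferative activity (on this read-out higher numbers stand for weaker inhibition and lower numbers for stronger inhibition), compound 1 (`COc1ccc(-c2snnc2-c2cc(OC)c(OC)c(OC)c2)cc1O`) gives 3 nM, while compound 2 (`COc1ccc(-c2snnc2-c2cc(OC)c(OC)c(OC)c2)cc1[N+](=O)[O-]`) gives 30.2 nM. Compound 3 (`COc1cc(-c2nnsc2-c2ccc([N+](=O)[O-])cc2)cc(OC)c1OC`) gives > 1000 nM in this assay, and this is a limit of the assay, not a number. Compound 3 therefore stands at the limit of > 1000 nM in this assay, at which 1 of the 3 values shown sits.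

Compound 4 (`COc1cc(-c2nnsc2-c2ccc(F)cc2)cc(OC)c1OC`) has not yet been measured. It carries fluoro in place of nitro on an aromatic carbon, para to a large group (fluoro in place of nitro on an aromatic carbon). Among the compounds with values here, only one measured step bears on this change, and only loosely: a 10-fold higher number from compound 1 to compound 2 (1.00 log units; beyond the scatter), where nitro entered and hydroxy left. That step is modest but beyond the scatter, and it went toward a higher number. Here nitro leaves instead, and a different group enters, so the earlier step offers a direction more than a size. Going by these compounds, with compound 3 known only as a limit, the size of the new step stays open. A modest move toward a lower number is expected, and the estimated step is an at least 1.4-fold lower number from compound 3 to compound 4 (0.15 log units; that floor lies within the scatter). For compound 4 the estimated value in this assay is 700 nM, with an expected range of 100 nM to 4000 nM.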

Compound 4, half-maximal inhibitory concentration: > 1000 nM
Compound 4 ended at the assay's limit; the forecaster's own chance of this, stated with the estimate: 45%; middle value at least 1.4-fold (0.15 log units) from the limit.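

In this assay, compound 3 and compound 4 both end at the assay's limit, so the step of fluoro in place of nitro cannot be read between them: the limit of > 1000 nM in this assay, at which 2 of the 4 values shown sit.

The compounds shown leave open how far either compound lies past that limit, and whether fluoro or nitro at this place gives the weaker inhibition.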